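The source may hold more compounds than are shown below. What is called first, only, known or untested is meant among the compounds shown, and "the series" means these compounds.

Measured so far in a functional assay on HEK293 cells for agonist activity at Glucose-dependent insulinotropic receptor (Homo sapiens), read by cAMP accumulation, with a stated time of 30 min; a higher number here means that more compound is needed for the effect, a lower number that less compound is needed:
Compound 1 `Cc1cc2c(c(Oc3cccc(NS(=O)(=O)c4ccc(Cl)cc4)c3)n1)C(=O)N(C1CC1)C2=O`: 15 nM
Compound 2 `Cc1cc2c(c(Oc3cccc(NS(=O)(=O)c4ccc(Cl)cc4)c3)n1)C(=O)N(C(C)C)C2=O`: 13 nM
Compound 3 `Cc1cc2c(c(Oc3cccc(S(=O)(=O)Nc4ccc(Cl)cc4)c3)n1)C(=O)N(C(C)C)C2=O`: 238 nM

Compound 3 gives the highest number of the three in this assay. The step of an 18-fold higher number from compound 2 to compound 3 (1.26 log units; beyond the scatter) is large, whereas a 1.2-fold lower number from compound 1 to compound 2 (0.06 log units; within the scatter) stays within the scatter. Compound 4 `Cc1cc2c(c(Oc3cccc(NC(=O)c4ccc(Cl)cc4)c3)n1)C(=O)N(C(C)C)C2=O` differs from compound 3 in one place: ((4-chlorophenyl)carbonyl)amino in place of (4-chlorophenyl)sulfamoyl on an aromatic carbon. Within the data shown here, the only measured step that bears on this change is an 18-fold higher number from compound 2 to compound 3 (1.26 log units; beyond the scatter), in which the group carrying its nitrogen on the aromatic carbon, ((4-chlorophenyl)sulfonyl)amino in compound 2, gave way to (4-chlorophenyl)sulfamoyl in compound 3, and the number rose sharply. Compound 4 returns to an arrangement with the nitrogen on the aromatic carbon, now as ((4-chlorophenyl)carbonyl)amino. Among the measured compounds shown here, no measured pair sets a carbonyl against a sulfonyl at this place, so how far the number moves back is uncertain. The expected step is therefore a 6.0-fold lower number from compound 3 to compound 4 (0.77 log units; beyond the scatter), toward a lower number, while falling short of compound 2 is held possible. Compound 4 is estimated at 40 nM in this assay, with a range from 10 nM to 160 nM.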

Compound 4, half-maximal effective concentration: > 30000 nM
Compound 4 was reported as a limit (the forecaster's own chance of this, stated with the estimate: 5%); middle value at least 750-fold (2.87 log units) away from the limit.
By their numbers in this assay, from the lowest: compounds 2 and 1 (each within the scatter of the next); then compound 3. At a limit, above all of these: compound 4.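

In this assay compound 4 is reported only at a limit of the assay, not as a number: the limit of > 30000 nM in this assay, at which 1 of the 4 values shown sits.

The earlier compounds shown here showed that moving from ((4-chlorophenyl)sulfonyl)amino to (4-chlorophenyl)sulfamoyl raised the number while still leaving a measurable value. With the nitrogen kept on the aromatic carbon, the result now shows a far larger loss for (4-chlorophenyl)carbonyl in place of (4-chlorophenyl)sulfonyl, an at least 2300-fold higher number from compound 2 to compound 4 (3.36 log units; beyond the scatter), so this position tolerates this exchange much less well than it tolerated the sulfonamide reversal. The second step, an at least 120-fold higher number from compound 3 to compound 4 (2.10 log units; beyond the scatter), shows that a nitrogen on the aromatic carbon does not by itself restore the low number of compound 2, and among these compounds the sulfonyl-bearing linkers give measurable values while the one carbonyl linker does not.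

As far as these compounds go, since compound 4 sits at a limit, the true size of both steps stays unknown, and a single carbonyl compound cannot show whether every such linker behaves alike. The compounds shown also leave open how a urea or a sulfamide linker would read at this place, and whether a methyl or methoxy group could replace the chlorine on the sulfonyl-bearing phenyl ring.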